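From compound 1 to compound 4: dimethylcarbamoyl for methoxy

The source may report more compounds than this note shows. Statements on the series, on what has been measured and on what is new or still open speak of the compounds shown alone.

In an ADME assay on S9 fraction from liver (Rattus norvegicus) for metabolic stability, with a stated time of 1 h (on this read-out higher numbers stand for a more stable compound and lower numbers for a less stable compound), compound 1 `CO[C@H]1CC[C@@H](Nc2cc(NCc3cnccc3C(F)(F)F)ncc2C#N)CC1` gives 1%. Compound 2 `N#Cc1cnc(NCc2cnccc2C(F)(F)F)cc1NC[C@H]1CC[C@H](O)CC1` gives 6%, and compound 3 `N#Cc1cnc(NCc2cnccc2C(F)(F)F)cc1NCCC1CCOCC1` gives 0%. All three lie within the scatter of one another, so compound 1 holds no distinct rank among them.

Compound 4 `CN(C)C(=O)[C@H]1CC[C@@H](Nc2cc(NCc3cnccc3C(F)(F)F)ncc2C#N)CC1` differs from compound 1 in one place: dimethylcarbamoyl in place of methoxy on a saturated ring carbon. In short, this is dimethylcarbamoyl in place of methoxy on a saturated ring carbon.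

Two measured steps start from compound 1 and change the same part of the structure: a number 5 percentage points higher from compound 1 to compound 2 (within the scatter) and a number 1 percentage points lower from compound 1 to compound 3 (within the scatter). Both replace the whole 4-methoxycyclohexyl group rather than the methoxy alone, so neither is a direct precedent. For the measured compounds named here, neither leaves the scatter, and no measured compound shows a clear gain. No step beyond the scatter is therefore expected, and the estimated change is a number 3 percentage points higher from compound 1 to compound 4 (within the scatter). For compound 4 the estimated value is 4%, with an expected range of 0% to 18%.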

Compound 4, percent of the compound remaining: 22%
The estimate for compound 4 lay 18 percentage points below the measured number, outside the stated range (above it).
By their numbers in this assay, from the lowest: compounds 3, 1 and 2 (each within the scatter of the next); then compound 4.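

For the compounds shown here, the change at this saturated ring carbon gives a number 21 percentage points higher from compound 1 to compound 4 (beyond the scatter) in this assay and is the only step in the set that lies beyond the scatter. The replacements of the whole 4-methoxycyclohexyl group, such as a number 5 percentage points higher from compound 1 to compound 2 (within the scatter) and a number 1 percentage points lower from compound 1 to compound 3 (within the scatter), stayed within it, whereas this step alters only the group on the ring carbon and leaves the rest of compound 1 in place, so that group alone can move this read-out. Nothing measured here accounts for the size of the step, which stands as an observation only.

As far as these compounds go, it remains open whether the step belongs to the carbonyl or to the dimethylamino part of the dimethylcarbamoyl group. A primary carboxamide, a carboxylic acid or a pyrrolidine amide on the same ring carbon would help to separate these parts.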